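This account rests on a few compounds, and the source may have more. Where it says the series, first, only, none or still open, it means among the compounds named here.

For the measured compounds named here, in a functional assay on DU-145 cells (Homo sapiens) for inhibition, read by trypan blue exclusion, with a stated time of 96 h (on this read-out lower numbers stand for stronger inhibition of growth and higher numbers for weaker inhibition of growth), compound 1 `O=C(O)c1ccc(C(=O)/C(=C\c2ccc(Cl)c([N+](=O)[O-])c2)SCc2ccc(F)cc2)cc1` gives 1000 nM, the lowest of the two numbers so far, and compound 2 `COc1ccc(/C=C(/SCc2ccc(F)cc2)C(=O)c2ccc(C(=O)O)cc2)cc1O` gives 10000 nM. Compound 3 `O=C(O)c1ccc(C(=O)/C(=C\c2ccc(Cl)c([N+](=O)[O-])c2)SCc2ccc(Cl)cc2Cl)cc1` differs from compound 1 by 2,4-dichlorophenyl in place of 4-fluorophenyl on a saturated chain carbon bound to a sulfur. Going by the values given here, the only measured step, a 10-fold higher number from compound 1 to compound 2 (1.00 log units; beyond the scatter), is modest and lies at a different place, the double-bonded chain carbon. Among the compounds with values here, no measured step covers the sulfur side, so no change beyond the scatter is expected in this assay. The estimated step is a 1.3-fold lower number from compound 1 to compound 3 (0.10 log units; within the scatter). Compound 3 is expected at 800 nM, within 250 nM to 2500 nM.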

Compound 3, concentration for 50% growth inhibition: 1000 nM
Beside the measured number, compound 3's estimate is 1.3-fold (0.10 log units) below it; the range from low to high includes it.
By their numbers in this assay, from the lowest: compounds 1 and 3 (each within the scatter of the next); then compound 2.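

In this assay the group on a saturated chain carbon bound to a sulfur can be exchanged: 2,4-dichlorophenyl in place of 4-fluorophenyl gives no change at the digits printed from compound 1 to compound 3 (within the scatter) and so leaves the read-out where it stood. This is a reading at the sulfur side, whereas the earlier step, a 10-fold higher number from compound 1 to compound 2 (1.00 log units; beyond the scatter), lies on the double-bonded chain carbon. As far as these compounds go, whether the number holds with an unsubstituted alkyl chain or an amine in place of these phenyl groups at this place remains open. No measured evidence here bears on why the two groups read alike.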